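The compounds below may be only part of what the source reports. "The series", "measured", "known", "first", "only" and "open" are said of these compounds alone.

Compound 1 `CC(=O)O[C@@H]1OC(n2nc(-c3ccccc3)n(/N=C/c3ccc(O)cc3)c2=S)[C@@H](C(C)=O)[C@H](OC(C)=O)[C@H]1OC(C)=O`: 12800 nM
Compound 2 `S=c1[nH]nc(-c2ccccc2)n1/N=C/c1ccccc1`: 31800 nM

Among the compounds with values here, in a functional assay on MCF7 cells (Homo sapiens) for antiproliferative activity, read by MTT assay, with a stated time of 24 h (a higher number here means a weaker inhibitor, a lower number a stronger inhibitor), compound 1 gives 12800 nM, the lower of the two numbers measured so far. Compound 2 gives 31800 nM, and the gap between the two lies beyond the usual scatter of such readings. Compound 3 `CC(=O)O[C@@H]1OC(n2nc(-c3ccccc3)n(/N=C/c3ccc(Cl)cc3)c2=S)[C@@H](C(C)=O)[C@H](OC(C)=O)[C@H]1OC(C)=O` is built from compound 1 by one change: chloro in place of hydroxy on an aromatic carbon. No comparison among the measured compounds shows what this exchange does in this assay. A modest move toward a lower number, or none beyond the scatter, is expected. Compound 3 is therefore estimated at 9000 nM, within 3000 nM to 30000 nM. The expected step is a 1.4-fold lower number from compound 1 to compound 3 (0.15 log units; within the scatter).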

Compound 3, half-maximal inhibitory concentration: 14100 nM
Compound 3: middle estimate off by 1.6-fold (0.19 log units), on the low side; the measured number falls inside the stated range.
By their numbers in this assay, from the lowest: compounds 1 and 3 (each within the scatter of the next); then compound 2.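

In this assay, chloro in place of hydroxy gives a 1.1-fold higher number from compound 1 to compound 3 (0.04 log units; within the scatter). On this ring, then, the hydrogen-bond donor and acceptor of the hydroxy group can go without a shift beyond the usual scatter, so neither appears to be needed at this position for this reading. Nothing available explains why the two compounds read alike. Still open, on these data alone, is whether an amine, a carboxylic acid or a methoxy group at the same place would also read alike, and whether a longer chain there would change the number.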